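The source may report more compounds than this note shows. Statements on the series, on what has been measured and on what is new or still open speak of the compounds shown alone.

Compound 1 `Cn1cncc1/C=N/Nc1ccnc2cc(Cl)ccc12` - 73.8 uM
Compound 2 `Clc1ccc2c(N/N=C/c3cccs3)ccnc2c1` - 10.4 uM

In a functional assay on KB cells (Homo sapiens) for cytotoxicity (on this read-out higher numbers stand for an effect only at larger amounts of compound and lower numbers for an effect already at smaller amounts), compound 2 has the lower of the two numbers (10.4 uM). Compound 3 `Cc1noc(C)c1/C=N/Nc1ccnc2cc(Cl)ccc12` differs from it at one place (3,5-dimethyl-1,2-oxazol-4-yl in place of thiophen-2-yl on a carbon with a double bond to nitrogen): 3,5-dimethyl-1,2-oxazol-4-yl in place of thiophen-2-yl on a carbon with a double bond to nitrogen. Going by the values given here, one measured step bears on this, a modest change at that same place (a 7.1-fold lower number from compound 1 to compound 2 (0.85 log units; beyond the scatter)). The entering group holds nitrogen, as does the group in compound 1 (73.8 uM), so part of that step may be given back. A modest rise is therefore expected (a 2.4-fold higher number from compound 2 to compound 3 (0.38 log units; beyond the scatter)). The estimated value for compound 3 is 25 uM (expected range 8 uM to 80 uM).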

Compound 3, concentration for half-maximal effect: 171 uM
Beside the measured number, compound 3's estimate is 6.8-fold (0.84 log units) below it, and the stated range ends below it.
By their numbers in this assay, from the lowest: compound 2; then compound 1; then compound 3.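

Going by these compounds alone, measured in this assay the place on the carbon with a double bond to nitrogen proves highly sensitive, since 3,5-dimethyl-1,2-oxazol-4-yl in place of thiophen-2-yl gives a 16-fold higher number from compound 2 to compound 3 (1.22 log units; beyond the scatter) and makes compound 3 the highest number so far. Holding nitrogen does not settle the number either, as the two nitrogen-bearing groups also differ, with a 2.3-fold higher number from compound 1 to compound 3 (0.36 log units; beyond the scatter) as the step. No measured evidence here accounts for these shifts.

From the compounds shown here alone, whether a plain phenyl ring, an amine or a longer chain at this place would land nearer compound 2 or compound 3 remains open. Also open, going by these compounds, is whether the two methyl groups or the ring itself carry the change.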